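Adding an Amino Group on Two Related Cores

The compounds below may be only part of what the source reports. "The series", "measured", "known", "first", "only" and "open" are said of these compounds alone.

Measured compounds:
Compound 1, `ClCc1ccc(Cn2cnc3c(Cl)ncnc32)cc1`, in a functional assay on U-251 cells (Homo sapiens) for cytotoxicity, read by sulforhodamine B assay, with a stated time of 48 h (on this read-out higher numbers stand for lower toxicity in this test and lower numbers for higher toxicity in this test), gives 7410 nM.
Compound 2, `Nc1nc(Cl)c2ncn(Cc3ccc(CCl)cc3)c2n1`, in this assay gives 44700 nM.
Compound 3, `ClCc1ccccc1Cn1cnc2c(Cl)ncnc21`, in this assay gives 61700 nM.

Compound 4, `Nc1nc(Cl)c2ncn(Cc3ccccc3CCl)c2n1`, has not yet been measured. It differs from compound 3 in one place: amino in place of hydrogen on an aromatic carbon. Compound 2 differs from compound 1 in exactly the same way: amino in place of hydrogen on an aromatic carbon. The surroundings of the change are the same in both pairs, so this is the same change made on two cores. Compounds 1 and 3 are built from the same atoms joined differently; the difference between the two cores is not broken down here. The numbers of compounds 2 and 3 lie within the usual scatter of each other, so nothing is read into their order. Compound 3 does give a higher number than compound 1, and that gap is beyond the scatter.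

Among the compounds with values here, the one measured instance of the change is a 6.0-fold higher number from compound 1 to compound 2 (0.78 log units; beyond the scatter), a modest step toward lower toxicity. Since the change occurs only once among the measured compounds, the expectation for compound 4 rests on that single pair. From compound 3 a step of similar size is expected, a 4.1-fold higher number from compound 3 to compound 4 (0.61 log units; beyond the scatter). For compound 4 the expected value is 250000 nM, with most repeated measurements expected to fall between 70000 nM and 800000 nM. A number this high may lie past what this test resolves, so a limit rather than a number is possible.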

Compound 4, concentration lethal to 50% of the cells: 72400 nM
Compound 4: middle estimate off by 3.5-fold (0.54 log units), on the high side; the measured number falls inside the stated range.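

In this assay, within the data shown here, putting amino in place of hydrogen on an aromatic carbon gives a 1.2-fold higher number from compound 3 to compound 4 (0.07 log units; within the scatter), so on the core of compound 3 this change leaves no step that can be told apart from repeat-to-repeat scatter. The size of the step therefore did not carry over from one core to the other, and the two pairs differ by more than ordinary scatter would explain: the same change on two cores in this assay, a 6.0-fold higher number (0.78 log units; beyond the scatter) from compound 1 to compound 2 and a 1.2-fold higher number (0.07 log units; within the scatter) from compound 3 to compound 4, 5.1-fold (0.71 log units) apart, beyond the scatter of two such steps. Among these compounds, this rests on only two pairs, one on each core, and it does not show why the cores respond differently or how the same change would behave on a third core.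

The compounds shown leave open whether a different group on the same aromatic carbon, such as a methylamino, hydroxyl or methoxy group, would also give steps that differ between the two cores. They also leave open whether a core built from the same atoms but joined in yet another way would follow the step seen on the core of compound 1, the one seen on the core of compound 3, or neither.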